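A few compounds are considered here, and "the series" means these few. Any claim that something is new, unique, unknown or untested is made for them only; others in the source may bear on it.

In a functional assay on the whole organism with Mus musculus as the target, in the maximal electroshock model (a higher number here means that more compound is needed for the effect, a lower number that less compound is needed), compound 1 `Nc1nnc(-c2ccccc2OCc2ccccc2)o1` gives 63.2 mg/kg. Compound 2 `Nc1nnc(-c2ccccc2OCc2ccc(F)cc2)o1` gives 3.3 mg/kg, and the step of a 19-fold lower number from compound 1 to compound 2 (1.28 log units; beyond the scatter) is the only large one among the measured compounds. Compound 3 `Sc1nnc(-c2ccccc2OCc2ccccc2)o1` reaches only a limit of the assay, >= 100 mg/kg. Compound 3 thus sits at the limit of >= 100 mg/kg in this assay, at which 1 of the 3 values shown sits, where the numbers shown run out. Compound 4 `CSc1nnc(-c2ccccc2OCc2ccccc2)o1` differs from compound 3 by methyl in place of hydrogen on a sulfur. Among the measured compounds shown here, of the measured steps, an at least 1.5-fold higher number from compound 1 to compound 3 (0.19 log units; that floor lies within the scatter) replaced the group on the same ring carbon, while the fluoro step touched a different ring; neither adds a methyl to a sulfur, so no measured step bears directly on this change, and no shift beyond the scatter is expected. Compound 4 is estimated at 100 mg/kg, within 25 mg/kg to 300 mg/kg, meaning an expected a number no higher from compound 3 to compound 4 (the limit leaves the size open).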

Compound 4, dose for half-maximal effect: > 100 mg/kg
Compound 4 gave a limit, no number; the forecaster's own chance of this, stated with the estimate: 50%; the middle value sits exactly at the limit.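

In this assay compound 4 gives a limit, not a number: the limit of > 100 mg/kg in this assay, at which 1 of the 4 values shown sits. Compound 3 also stands at a limit, so the step of methyl replacing hydrogen on the sulfur cannot be read: the limit of >= 100 mg/kg in this assay, at which 1 of the 4 values shown sits. Replacing amino with methylsulfanyl gives an at least 1.5-fold higher number from compound 1 to compound 4 (0.19 log units; that floor lies within the scatter), so a second sulfur group at this place also yields no readable number.

Still open, as far as these compounds go, is whether a longer chain on the sulfur, such as ethylsulfanyl, or a carboxylic acid in place of the amino group would give a readable number. Also open, from the compounds shown here alone, is whether the fluoro change would have any effect alongside methylsulfanyl.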